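A few compounds are considered here, and "the series" means these few. Any claim that something is new, unique, unknown or untested is made for them only; others in the source may bear on it.

Measured compounds:
Compound 1, `CC1CCC(=O)N1CC#CCn1ccnc1`: > 100 mg/kg
Compound 2, `Cc1cncn1CC#CCN1C(=O)CCC1C`: > 100 mg/kg
Compound 3, `Cn1ccn(CC#CCn2ccnc2)c1=O`: 4.5 mg/kg

All three compounds were tested in a functional assay on the whole organism for agonist activity, with Mus musculus as the target; on this read-out higher numbers stand for an effect only at larger amounts of compound and lower numbers for an effect already at smaller amounts. Compound 1 gives > 100 mg/kg, which is a limit of the assay rather than a number. Compound 2 likewise gives > 100 mg/kg, again a limit and not a number. Compound 2 arises from compound 1 by the change (methyl in place of hydrogen on an aromatic carbon); the step this change made, a step that the two limits leave unreadable from compound 1 to compound 2, cannot be read, since both ends of it sit at the limit of > 100 mg/kg in this assay, at which 2 of the 3 values shown sit. Going by the values given here, compound 3 gives 4.5 mg/kg, the only real number among the three. Compound 3 carries a different core from compound 1, and the difference between the two cores is not broken down here.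

Compound 4, `Cc1cncn1CC#CCn1ccn(C)c1=O`, has not yet been measured. Among the compounds with values here, it differs from compound 3 by methyl in place of hydrogen on an aromatic carbon, which is the same change as the one from compound 1 to compound 2. Within the data shown here, the only measured instance of this change gave no readable size, so the expectation for compound 4 rests mainly on compound 3 and its value 4.5 mg/kg. In this assay compound 4 is expected to come out near 6 mg/kg, with a plausible range from 1.5 mg/kg to 30 mg/kg. Among the measured compounds shown here, this amounts to an expected step of a 1.3-fold higher number from compound 3 to compound 4 (0.12 log units; within the scatter), which is deliberately kept modest, as there is no measured step of readable size to lean on.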

Compound 4, dose for half-maximal effect: 100 mg/kg
Estimate against measurement, compound 4: 17-fold (1.22 log units) below, outside the stated range (above it).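

In this assay, methyl in place of hydrogen on an aromatic carbon gives a 22-fold higher number from compound 3 to compound 4 (1.35 log units; beyond the scatter), so on the core of compound 3 this small change costs a great deal: far more compound is needed for the same effect. On the core of compound 1, the same change cannot be read, because compound 1 and compound 2 each give a limit of the assay rather than a number: the limit of > 100 mg/kg in this assay, at which 2 of the 4 values shown sit. This leaves a single readable instance of the change, which shows that it can have a large effect in this series but not whether an effect of this size carries from one core to another, and nothing shown explains why the step is so large.

The compounds shown leave open what other groups would do at this same aromatic carbon, for example an ethyl group, an amine or a carboxylic acid, and so whether the loss is specific to methyl. They also leave open how the change would behave on a core where both the compound with hydrogen and the compound with methyl give real numbers.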